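A Small Swap at One Aromatic Carbon

A few compounds are considered here, and "the series" means these few. Any claim that something is new, unique, unknown or untested is made for them only; others in the source may bear on it.

In a functional assay on MDA-MB-231 cells (Homo sapiens) for inhibition, read by MTT assay, with a stated time of 72 h (a higher number here means a weaker inhibitor, a lower number a stronger inhibitor), compound 1 `COc1ccc(-c2cc(C(=O)N3CCC4(CC3)CC(=O)c3nn(C(C)(C)C)cc3O4)c3ccccc3n2)cc1OC` gives 7130 nM and compound 2 `Cc1cc(C(=O)N2CCC3(CC2)CC(=O)c2nn(C(C)(C)C)cc2O3)c2ccccc2n1` gives 4860 nM as its reading. For the measured compounds named here, these two numbers lie within the usual scatter of each other, so compound 2 stands level with the only other compound measured. Compound 3 `COc1cc(C(=O)N2CCC3(CC2)CC(=O)c2nn(C(C)(C)C)cc2O3)c2ccccc2n1` keeps the core of compound 2 and carries methoxy in place of methyl on an aromatic carbon, next to the ring nitrogen methoxy in place of methyl on an aromatic carbon and nothing else differs. Going by the values given here, one measured step bears on this carbon: methyl in place of 3,4-dimethoxyphenyl, a 1.5-fold lower number from compound 1 to compound 2 (0.17 log units; within the scatter) and so a far bigger exchange of atoms left the number within the scatter. No step beyond the scatter is therefore expected in this assay for this smaller swap. The estimated change is a 1.0-fold higher number from compound 2 to compound 3 (0.01 log units; within the scatter) and it stays within the scatter. For compound 3 the estimated value is 5000 nM with 2000 nM to 12000 nM as the expected range.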

Compound 3, half-maximal inhibitory concentration: > 10000 nM
Compound 3 gave a limit, no number; the forecaster's own chance of this, stated with the estimate: 5%; middle value at least 2.0-fold (0.30 log units) from the limit.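

Compound 3 gives no number, only a limit of the assay: the limit of > 10000 nM in this assay, at which 1 of the 3 values shown sits.

Even so, the limit is enough to show that this carbon does not tolerate every small swap in this assay: methoxy in place of methyl gives an at least 2.0-fold higher number from compound 2 to compound 3 (0.31 log units; beyond the scatter), while the much larger exchange from compound 1 to compound 2 stayed within the scatter. Set against the larger group, methoxy in place of 3,4-dimethoxyphenyl gives an at least 1.4-fold higher number from compound 1 to compound 3 (0.14 log units; that floor lies within the scatter), so this floor does not separate that pair.

As far as these compounds go, only methyl, methoxy and 3,4-dimethoxyphenyl sit on this carbon here, so it remains open how an amine, a hydroxyl or an ethyl chain would read in this assay at the same place. The limit also leaves open how far compound 3 truly lies from compound 2.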